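A few compounds are considered here, and "the series" means these few. Any claim that something is new, unique, unknown or untested is made for them only; others in the source may bear on it.

Compound 1 `CCOC(=O)c1c(-c2cccc(OC)c2)[nH]c2cc(OC)ccc2c1=O`: > 21500 nM, a limit.
Compound 2 `CCOC(=O)c1c(-c2cccc(OC)c2)[nH]c2cc(OC)c(Cl)cc2c1=O`: > 21500 nM, a limit.
Compound 3 `CCOC(=O)c1c(-c2cccc(Br)c2)[nH]c2cc(OC)c(Cl)cc2c1=O`: > 21500 nM, a limit.

In an ADME assay on HepG2 cells (Homo sapiens) for cytotoxicity, read by luminescence, with a stated time of 72 h (on this read-out higher numbers stand for an effect only at larger amounts of compound and lower numbers for an effect already at smaller amounts), compound 2 reads only as a limit, and it shares (the limit of > 21500 nM in this assay, at which 3 of the 3 values shown sit). Compound 4 `CCOC(=O)c1c(-c2cccc(OC)c2)[nH]c2cc(OC)c(F)cc2c1=O` differs from compound 2 by one change: fluoro in place of chloro on an aromatic carbon. The closest measured change is a step that the two limits leave unreadable from compound 1 to compound 2, which touches the same aromatic carbon. The other is a step that the two limits leave unreadable from compound 2 to compound 3, at a different place. Neither has a size that can be read, so no step beyond the scatter is expected in this assay, and no direction can be drawn from the data. The expected change is a step that the limit leaves unreadable from compound 2 to compound 4. Compound 4 is estimated at 30000 nM, with an expected range from 18000 nM to 60000 nM, and it will most likely also report only a limit.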

Compound 4, half-maximal effective concentration: > 21500 nM
Compound 4: only a limit was reported; the forecaster's own chance of this, stated with the estimate: 85%; the middle value does not contradict the limit.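

In this assay, going by these compounds alone, compound 4 reads only as a limit, so no step to it from compound 1 or compound 2 can be read. The compounds shown leave open whether any of these changes alters the read-out at all.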